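The source may report more compounds than this note shows. Statements on the series, on what has been measured and on what is new or still open speak of the compounds shown alone.

Compound 1 `C=C[C@@](C)(/C=C/c1ccc(O)cc1)CC/C=C/C#N`: > 36600 nM, a limit
Compound 2 `C=C[C@@](C)(/C=C/c1ccc(O)c(C=O)c1)CCC=C(C)C`: > 36600 nM, a limit

Both readings come from an ADME assay on BJ cells (Homo sapiens) for cytotoxicity, with a stated time of 72 h; on this read-out lower numbers stand for an effect already at smaller amounts and higher numbers for an effect only at larger amounts of compound. Neither is a number, and the whole record so far is the limit of > 36600 nM in this assay, at which 2 of the 2 values shown sit. For the measured compounds named here, compound 2 therefore stands only at its limit of > 36600 nM, and no measured step shows what a change at any one place does.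

Compound 3 `C=C[C@@](C)(/C=C/c1ccc(O)c(/C=C(\C)C(=O)OCC)c1)CCC=C(C)C` is the next compound to be read. It carries 2-(ethoxycarbonyl)prop-1-en-1-yl in place of formyl on an aromatic carbon, ortho to a hydroxy group and meta to a large group (2-(ethoxycarbonyl)prop-1-en-1-yl in place of formyl on an aromatic carbon).

With compound 2 at the limit of > 36600 nM, no step beyond the scatter is expected in this assay. If a number does appear, it can only lie toward an effect at smaller amounts, and a further limit remains the likelier result. The estimated change is a number no higher from compound 2 to compound 3 (the limit leaves the size open). For compound 3 the expected value is 36600 nM, with an estimated range of 15000 nM to 60000 nM.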

Compound 3, half-maximal effective concentration: > 36600 nM
Compound 3 ended at the assay's limit; the forecaster's own chance of this, stated with the estimate: 70%; the middle value sits exactly at the limit.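

Compound 2 and compound 3 both end as limits in this assay, so no step can be read for 2-(ethoxycarbonyl)prop-1-en-1-yl in place of formyl. The compounds shown leave open what any change at this place does to the read-out, and at what amount of compound any of them would show an effect, with the whole record resting on one limit: the limit of > 36600 nM in this assay, at which 3 of the 3 values shown sit.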